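The source may hold more compounds than are shown below. What is called first, only, known or untested is meant among the compounds shown, and "the series" means these compounds.

Measured so far:
Compound 1 `CCCCCCOc1nc(C(F)(F)Cl)ccc1CNC(=O)C(C)c1ccc(NS(C)(=O)=O)c(F)c1` gives 0.8 nM in an assay on CHO cells for antagonist activity at transient receptor potential cation channel subfamily V member 1 (Homo sapiens), read by FLIPR; on this read-out higher numbers stand for weaker inhibition and lower numbers for stronger inhibition.
Compound 2 `CC(C)COc1nc(C(F)(F)Cl)ccc1CNC(=O)C(C)c1ccc(NS(C)(=O)=O)c(F)c1` gives 0.6 nM.

Of the two numbers in this assay, compound 2 has the lower one, yet its gap to compound 1 is within the scatter. Compound 3 `CC(C(=O)NCc1ccc(C(F)(F)Cl)nc1OC1CCCCC1)c1ccc(NS(C)(=O)=O)c(F)c1` differs from compound 2 by cyclohexyl in place of isobutyl on an oxygen on an aromatic ring. For the measured compounds named here, only one measured step touches this position, a 1.3-fold lower number from compound 1 to compound 2 (0.12 log units; within the scatter), a swap of the chain on the same oxygen that left the number within the scatter. The expected step is therefore a 1.3-fold higher number from compound 2 to compound 3 (0.12 log units; within the scatter), nothing beyond the scatter. Compound 3 is estimated at 0.8 nM, with a likely range from 0.3 nM to 2.5 nM.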

Compound 3, inhibition constant: 0.9 nM
Estimate against measurement, compound 3: 1.1-fold (0.05 log units) below; low and high end bracket the measured number.
By their numbers in this assay, from the lowest: compounds 2, 1 and 3 (each within the scatter of the next).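

Moving from an open chain to a ring on the oxygen on the aromatic ring leaves the number in this assay within the scatter: cyclohexyl in place of isobutyl gives a 1.5-fold higher number from compound 2 to compound 3 (0.18 log units; within the scatter) and cyclohexyl in place of hexyl gives a 1.1-fold higher number from compound 1 to compound 3 (0.05 log units; within the scatter) with neither step beyond it. Isobutyl, hexyl and cyclohexyl therefore all give closely matching numbers here. No measurement shown explains why these numbers stay so close.

As far as these compounds go, whether this holds for a much smaller group such as methyl, or for a chain ending in an amine or a carboxylic acid, stays open. A phenyl ring on this oxygen is also an open case.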